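Benzodioxinyl amide replaces chloro-trifluoromethylphenyl amide

The source may hold more compounds than are shown below. What is called first, only, known or untested is meant among the compounds shown, and "the series" means these compounds.

Three compounds share a core and differ only in the aryl group attached to the amide carbonyl. Compound 1 `COc1ccc(C(=O)Nc2cccc(-c3ccnc4c(NC(C)=O)cccc34)c2)cc1OC` gives 5300 nM in a functional assay on A375P cells (Homo sapiens) for antiproliferative activity, read by MTT assay, with a stated time of 48 h; on this read-out lower numbers stand for stronger inhibition and higher numbers for weaker inhibition. Compound 2 `CC(=O)Nc1cccc2c(-c3cccc(NC(=O)c4cccc(C(F)(F)F)c4)c3)ccnc12` gives 8000 nM in this assay, and compound 3 `CC(=O)Nc1cccc2c(-c3cccc(NC(=O)c4ccc(C(F)(F)F)c(Cl)c4)c3)ccnc12` gives 7600 nM. Compound 3 thus stands second highest of the three numbers; its nearest neighbour is compound 2, and the step of a 1.1-fold lower number from compound 2 to compound 3 (0.02 log units; within the scatter) lies within the scatter. The step of a 1.4-fold higher number from compound 1 to compound 3 (0.16 log units; within the scatter) is also within the scatter, as is a 1.5-fold higher number from compound 1 to compound 2 (0.18 log units; within the scatter). Nothing among these three aryl groups moved the number beyond the usual spread.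

Compound 4 `CC(=O)Nc1cccc2c(-c3cccc(NC(=O)c4ccc5c(c4)OCCO5)c3)ccnc12` carries the change (2,3-dihydro-1,4-benzodioxin-6-yl in place of 3-chloro-4-(trifluoromethyl)phenyl on a carbonyl carbon). The measured steps that bear on it are those exchanging one aryl group for another on this carbonyl carbon, and all of them stayed within the scatter; the closest analogue is the move from compound 1 to compound 3, which also exchanged a ring bearing two oxygens for the chloro-trifluoromethyl ring. He therefore expects no step beyond the scatter for compound 4, with an estimated 1.4-fold lower number from compound 3 to compound 4 (0.14 log units; within the scatter) in this assay. For compound 4 he estimates 5500 nM, expected to fall between 2500 nM and 12000 nM.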

Compound 4, half-maximal inhibitory concentration: 570 nM
Compound 4: middle estimate off by 9.6-fold (0.98 log units), on the high side, and the stated range ends above it.
By their numbers in this assay, from the lowest: compound 4; then compounds 1, 3 and 2 (each within the scatter of the next).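

At this carbonyl carbon, the aryl group can matter after all: in this assay the 2,3-dihydro-1,4-benzodioxin-6-yl group gives a 13-fold lower number from compound 3 to compound 4 (1.12 log units; beyond the scatter) and a 14-fold lower number from compound 2 to compound 4 (1.15 log units; beyond the scatter) and so leaves the scatter that had held all the earlier exchanges, which makes compound 4 the strongest of the four. Oxygen on the ring is not enough on its own to give this result, for the same comparison gives a 9.3-fold lower number from compound 1 to compound 4 (0.97 log units; beyond the scatter) even though compound 1, with its 3,4-dimethoxyphenyl group, also carries two oxygens and stays within the scatter of compound 2 and compound 3; among these compounds, only compound 4 has the oxygens closed into a six-membered non-aromatic ring. Nothing shown here offers any measurement that could explain the drop in the number.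

On these data alone, what remains open is whether the low number depends on this exact ring, and a 1,3-benzodioxol-5-yl group or a 2,3-dihydrobenzofuran-5-yl group would test its size and its need for both oxygens. As far as these compounds go, it is also open whether the same exchange would hold on a core carrying an amine in place of the acetamide, or on cells other than these.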